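A few compounds are considered here, and "the series" means these few. Any claim that something is new, unique, unknown or untested is made for them only; others in the source may bear on it.

Of the compounds shown here, three have so far been tested in a functional assay on MCF7 cells (Homo sapiens) for antiproliferative activity, read by MTT assay, with a stated time of 72 h; a lower number here means a stronger inhibitor, a higher number a weaker inhibitor. Compound 1 `COc1ccc2oc(CSC(=S)N3CCOCC3)cc(=O)c2c1` reaches only the limit of this assay, giving > 25000 nM. Compound 2 `O=c1cc(CSC(=S)N2CCCCC2)oc2ccccc12` likewise shows only a limit, > 25000 nM. For the measured compounds named here, compound 3 `CC(C)N(C(=S)SCc1cc(=O)c2ccccc2o1)C(C)C` is the single compound with a readable number, giving 31700 nM in this assay, so it stands as the only real value among the three. The step that the limit leaves unreadable from compound 2 to compound 3 cannot be sized because the limit of > 25000 nM in this assay, at which 2 of the 3 values shown sit, is where compound 2 sits. Compound 4 `O=c1cc(CSC(=S)N2CCOCC2)oc2ccccc12` alters compound 3 by morpholin-4-yl in place of diisopropylamino on a thiocarbonyl carbon. Going by the values given here, no measured step speaks directly to this change, and the one related step is unreadable. The step of a 1.3-fold higher number from compound 3 to compound 4 (0.10 log units; within the scatter) is therefore expected to be small. Compound 4 is estimated at 40000 nM, within a range from 15000 nM to 120000 nM, and may well be reported only as a limit.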

Compound 4, half-maximal inhibitory concentration: 21000 nM
For compound 4 the middle estimate is 1.9-fold (0.28 log units) above the measured one; measured number inside the range.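

In this assay, morpholin-4-yl in place of diisopropylamino on the thiocarbonyl carbon gives a 1.5-fold lower number from compound 3 to compound 4 (0.18 log units; within the scatter), so the open-chain group and the ring cannot be told apart here. The other two changes, morpholin-4-yl for piperidin-1-yl and hydrogen for methoxy, give only floors: an at least 1.1-fold lower number from compound 2 to compound 4 (0.07 log units; that floor lies within the scatter) and an at least 1.1-fold lower number from compound 1 to compound 4 (0.07 log units; that floor lies within the scatter). These floors rest on limits, not numbers: the limit of > 25000 nM in this assay, at which 2 of the 4 values shown sit.

From the compounds shown here alone, it remains open whether a piperazin-1-yl group on that thiocarbonyl carbon, or a chlorine on the aromatic carbon, would move the number beyond the scatter.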